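From compound 2 to compound 4: one group exchanged

The compounds below may be only part of what the source reports. "The series", "measured", "known", "first", "only" and "open" are said of these compounds alone.

Compound 1 `Cc1ccccc1-c1cccc(NC(=O)C(Cl)Cl)c1`: 42000 nM
Compound 2 `COc1cccc(-c2cccc(NC(=O)C(Cl)Cl)c2)c1`: 43300 nM
Compound 3 `COc1cccc(-c2cc(NC(=O)C(Cl)Cl)cc(-c3cccc(OC)c3)c2)c1`: > 30000 nM (a limit, not a number)

These values come from a functional assay on KB 3-1 cells (Homo sapiens) for cytotoxicity, read by MTT assay, with a stated time of 68 h; on this read-out higher numbers stand for weaker inhibition and lower numbers for stronger inhibition. Compound 1 gives 42000 nM and compound 2 gives 43300 nM, and these two numbers lie within the usual scatter of each other. Compound 4 `O=C(Nc1cccc(-c2cccc(NC(=O)C(Cl)Cl)c2)c1)C(Cl)Cl` keeps the core of compound 2 but carries ((dichloromethyl)carbonyl)amino in place of methoxy on an aromatic carbon.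

Going by the values given here, only one measured step starts from compound 2, and it changes a different place. This is a step that the limit leaves unreadable from compound 2 to compound 3, which rests on (the limit of > 30000 nM in this assay, at which 1 of the 3 values shown sits). It therefore gives no size to build on. With no readable step as a guide, the value of compound 2, 43300 nM, remains the best starting point, and no clear direction can be expected. The expected result is a 1.2-fold lower number from compound 2 to compound 4 (0.09 log units; within the scatter), which would be no change beyond the scatter. For compound 4 the estimated value is 35000 nM, with an expected range from 12000 nM to 90000 nM.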

Compound 4, half-maximal inhibitory concentration: > 50000 nM
Compound 4: a limit, no number (the forecaster's own chance of this, stated with the estimate: 30%); at least 1.4-fold (0.15 log units) between middle value and limit.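

Unlike the earlier compounds, this step changes the methoxy group itself: in this assay, putting ((dichloromethyl)carbonyl)amino on the same aromatic carbon gives an at least 1.1-fold higher number from compound 2 to compound 4 (0.06 log units; that floor lies within the scatter). This second copy of the dichloroacetyl amide already carried by the core therefore brings no sign of stronger inhibition at this place, although the floor of the step does not show weaker inhibition beyond the scatter. Compound 4 gives a limit of the assay and not a number, so the step has a floor but no full size: the limit of > 50000 nM in this assay, at which 1 of the 4 values shown sits.

From the compounds shown here alone, the true value of compound 4 remains open, so the full size of this change is unknown. Also open, going by these compounds, is whether an amine or a carboxylic acid on this aromatic carbon would move the number beyond the scatter in either direction.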